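The compounds below may be only part of what the source reports. "The series", "measured", "known", "first", "only" and "open" are said of these compounds alone.

Measured so far in a functional assay on MCF7 cells (Homo sapiens) for cytotoxicity, read by MTT assay, with a stated time of 72 h; on this read-out higher numbers stand for weaker inhibition and lower numbers for stronger inhibition: compound 1 `Cc1ccc(COc2cc(O)c3c(=O)cc(-c4ccccc4)oc3c2OCCCCN2CCN(C)CC2)cc1` gives 2220 nM; compound 2 `CN1CCN(CCCCOc2c(OCc3ccc(C#N)cc3)cc(O)c3c(=O)cc(-c4ccccc4)oc23)CC1` gives 2420 nM.

Compound 2 carries the highest of the two numbers in this assay, with compound 1 nearest; the step of a 1.1-fold higher number from compound 1 to compound 2 (0.04 log units; within the scatter) lies within the scatter, so the two compounds are not separated by the data. Compound 3 `CN1CCN(CCCCOc2c(OCc3ccco3)cc(O)c3c(=O)cc(-c4ccccc4)oc23)CC1` is not yet measured. Its change from compound 2 is furan-2-yl in place of 4-cyanophenyl on a saturated chain carbon bound to an oxygen on an aromatic ring. Among the measured compounds shown here, the only measured step, a 1.1-fold higher number from compound 1 to compound 2 (0.04 log units; within the scatter), touches the group on the same saturated chain carbon bound to an oxygen on an aromatic ring and produced nothing beyond the scatter. For the measured compounds named here, no measured step replaces the whole aromatic ring at that place, so the expectation rests on that single result alone. Compound 3 is therefore expected to sit close to compound 2, with an expected step of a 1.0-fold higher number from compound 2 to compound 3 (0.01 log units; within the scatter) that stays within the scatter. The estimate for compound 3 in this assay is 2500 nM, in the range 1100 nM to 5600 nM.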

Compound 3, half-maximal inhibitory concentration: 2770 nM
Compound 3: middle estimate off by 1.1-fold (0.04 log units), on the low side, within the range that was stated.
By their numbers in this assay, from the lowest: compounds 1, 2 and 3 (each within the scatter of the next).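

In this assay, furan-2-yl in place of 4-cyanophenyl on a saturated chain carbon bound to an oxygen on an aromatic ring gives a 1.1-fold higher number from compound 2 to compound 3 (0.06 log units; within the scatter), and furan-2-yl in place of 4-methylphenyl at the same place gives a 1.2-fold higher number from compound 1 to compound 3 (0.10 log units; within the scatter). The earlier step changed only the group carried on the six-membered aromatic ring of carbon only, whereas these steps replace that ring with a five-membered aromatic ring with 1 hetero atom, and the three compounds still remain unseparated by the data. No accompanying measurement explains this absence of separation.

From the compounds shown here alone, whether an amine, a carboxylic acid or a cyclohexyl group at this place would give a step beyond the scatter remains open. The rest of the structure is constant across the three compounds, so these results say nothing about its contribution.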